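A few compounds are considered here, and "the series" means these few. Any claim that something is new, unique, unknown or untested is made for them only; others in the source may bear on it.

In a functional assay on HCT-116 cells (Homo sapiens) for inhibition, read by CCK-8 assay, with a stated time of 72 h, tested at 8 uM; on this read-out higher numbers stand for more inhibition of growth at the one concentration tested and lower numbers for less inhibition of growth:
- Compound 1 `Nc1ccccc1NC(=O)/C=C/c1ccc(CSc2ccc(Cl)cc2)cc1`: 3.27%
- Compound 2 `Nc1ccccc1NC(=O)/C=C/c1ccc(CSc2cccc3ccccc23)cc1`: 35.2%

Compound 2 is the higher of the two measured compounds. Compound 3 `CC(C)(C)c1ccc(SCc2ccc(/C=C/C(=O)Nc3ccccc3N)cc2)cc1` changes it as follows: 4-(tert-butyl)phenyl in place of naphthalen-1-yl on a sulfur. For the measured compounds named here, only one measured step bears on this change: a number 31.9 percentage points higher from compound 1 to compound 2 (beyond the scatter), beyond the scatter, with naphthalen-1-yl in place of 4-chlorophenyl on the same sulfur. Compound 3 gives up naphthalen-1-yl and, like compound 1, has a substituted phenyl there, so a moderate fall in this assay is expected, though a single step is thin evidence. The expected change is a number 17.2 percentage points lower from compound 2 to compound 3 (beyond the scatter). For compound 3 the estimated value is 18%, with an expected range of 3% to 42%.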

Compound 3, percent growth inhibition at one concentration: 39%
The estimate for compound 3 lay 21 percentage points below the measured number; low and high end bracket the measured number.
By their numbers in this assay, from the lowest: compound 1; then compounds 2 and 3 (each within the scatter of the next).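

In this assay the change to 4-(tert-butyl)phenyl on the sulfur gives a number 3.8 percentage points higher from compound 2 to compound 3 (within the scatter) and so shows that one aromatic ring can serve here as well as the two of naphthalen-1-yl. A substituted phenyl is therefore not poor in itself, since tert-butyl in place of chloro on an aromatic carbon gives a number 35.7 percentage points higher from compound 1 to compound 3 (beyond the scatter) and the choice of substituent matters. No measurement here explains either step.

Still open, as far as these compounds go, is how an amine or a carboxylic acid in place of tert-butyl would fare in this assay and whether a longer chain would be tolerated on the sulfur.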